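Adding a sulfonyl group to compound 2

The source may hold more compounds than are shown below. What is called first, only, known or untested is meant among the compounds shown, and "the series" means these compounds.

Compound 1 `CN1C/C(=C\c2ccncc2)C(=O)/C(=C/c2ccc(C#N)cc2)C1` gives 14000 nM
Compound 2 `O=C1/C(=C/c2cccnc2)CNC/C1=C\c1ccccc1F` gives 15900 nM

These values come from an ADME assay on L02 cells (Homo sapiens) for cytotoxicity, read by MTT assay, with a stated time of 24 h (a higher number here means a weaker inhibitor, a lower number a stronger inhibitor), and are the only ones at hand. Compound 2 at 15900 nM stands within the scatter of compound 1 at 14000 nM and the two cannot be ranked. Compound 3 `O=C1/C(=C/c2cccnc2)CN(S(=O)(=O)c2ccc(Br)cc2)C/C1=C\c1ccccc1F` has (4-bromophenyl)sulfonyl in place of hydrogen on an amine nitrogen in a ring of compound 2 ((4-bromophenyl)sulfonyl in place of hydrogen on an amine nitrogen in a ring). Within the data shown here, no measured pair shows such a change, so any forecast remains uncertain. A modest step towards a lower number in this assay is expected, just beyond the scatter. The expected step is a 2.4-fold lower number from compound 2 to compound 3 (0.39 log units; beyond the scatter) in this estimate. Compound 3 is estimated at 6500 nM (range 2000 nM to 20000 nM).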

Compound 3, half-maximal inhibitory concentration: 14600 nM
Compound 3: middle estimate off by 2.2-fold (0.35 log units), on the low side, and the stated range covers the measured number.
By their numbers in this assay, from the lowest: compounds 1, 3 and 2 (each within the scatter of the next).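

On the amine nitrogen in a ring, (4-bromophenyl)sulfonyl in place of hydrogen gives a 1.1-fold lower number from compound 2 to compound 3 (0.04 log units; within the scatter) in this assay. Among these compounds, this is the first reading of a change at this position, and even a substituent of 10 heavy atoms leaves the two numbers impossible to tell apart. Nothing measured here bears on why this is so.

On these data alone, it remains open whether the sulfonyl link or the 4-bromophenyl part governs this reading. An acetyl or a methanesulfonyl group on the same nitrogen could separate the two.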